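A Phenyl in Place of Dimethylamino: the Expected Step

The compounds below may be only part of what the source reports. "The series", "measured", "known", "first", "only" and "open" are said of these compounds alone.

Of the compounds shown here, three sharing one core have been tested in a functional assay on K562 cells (Homo sapiens) for antiproliferative activity, read by MTT assay, with a stated time of 24 h; a lower number here means a stronger inhibitor, a higher number a weaker inhibitor. Compound 1 `COc1ccc(C(=O)/C=C/c2ccc(F)cc2)c2c1C=CC(C)(C)O2` carries fluoro on its terminal aromatic ring; in this assay compound 1 gives only a limit, > 10000 nM. Compound 2 `COc1ccc(C(=O)/C=C/c2ccc(Br)cc2)c2c1C=CC(C)(C)O2`, with bromo in place of fluoro, likewise gives only a limit in this assay, > 10000 nM. The step that the two limits leave unreadable from compound 1 to compound 2 therefore cannot be sized. For the measured compounds named here, compound 3 `COc1ccc(C(=O)/C=C/c2ccc(N(C)C)cc2)c2c1C=CC(C)(C)O2`, bearing dimethylamino, is the only one with a number: in this assay compound 3 gives 3500 nM. Going by the values given here, compound 3 thus stands as the sole measured value, with the steps of an at least 2.8-fold lower number from compound 1 to compound 3 (0.45 log units; beyond the scatter) and an at least 2.8-fold lower number from compound 2 to compound 3 (0.45 log units; beyond the scatter) both pointing toward it, each readable only as a lower bound because of the limit of > 10000 nM in this assay, at which 2 of the 3 values shown sit.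

Compound 4 `COc1ccc(C(=O)/C=C/c2ccc(-c3ccccc3)cc2)c2c1C=CC(C)(C)O2` differs from compound 3 by phenyl in place of dimethylamino on an aromatic carbon. Among the compounds with values here, the steps that bear on this change are the two that introduced dimethylamino, an at least 2.8-fold lower number from compound 1 to compound 3 (0.45 log units; beyond the scatter) and an at least 2.8-fold lower number from compound 2 to compound 3 (0.45 log units; beyond the scatter); removing dimethylamino again runs against them, and phenyl brings no hydrogen-bond acceptor where the group it replaces had one. The writer therefore expects a step of a 2.3-fold higher number from compound 3 to compound 4 (0.36 log units; beyond the scatter) in this assay for compound 4, toward a higher number. The estimate for compound 4 is 8000 nM, with a range from 3000 nM to 20000 nM, and a fair chance that this assay again reports only a limit.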

Compound 4, half-maximal inhibitory concentration: > 10000 nM
Compound 4: only a limit was reported; the forecaster's own chance of this, stated with the estimate: 50%; middle value at least 1.2-fold (0.09 log units) from the limit.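

In this assay compound 4 gives > 10000 nM, which is a limit of the assay and not a number. Phenyl in place of dimethylamino on this aromatic carbon, para to a large group, gives an at least 2.8-fold higher number from compound 3 to compound 4 (0.45 log units; beyond the scatter), showing that a second large terminal group, this one a six-membered aromatic ring of carbon only, does not keep the measurable activity of compound 3; until now, only fluoro and bromo had been seen to fall short of it, so among the four groups shown, dimethylamino alone now gives a number. The steps to compound 4 from compound 1 and from compound 2 cannot be read, because all three compounds sit at the same limit: the limit of > 10000 nM in this assay, at which 3 of the 4 values shown sit.

The compounds shown leave open whether the nitrogen of dimethylamino matters here, since neither another amine such as morpholine or pyrrolidine nor a methoxy group at this place appears among them. They also leave open how compound 1, compound 2 and compound 4 rank against one another, and whether any of them differs at all.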